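A few compounds are considered here, and "the series" means these few. Any claim that something is new, unique, unknown or untested is made for them only; others in the source may bear on it.

Of the compounds shown here, three have been measured in a functional assay on B16-F10 cells (Mus musculus) for inhibition, read by MTT assay, with a stated time of 72 h; on this read-out lower numbers stand for stronger inhibition and higher numbers for weaker inhibition. Compound 1 `C#CCSc1nc(Nc2ccc(OC)cc2)c(C#N)c(-c2ccccc2)n1` gives 9710 nM and compound 2 `C#CCSc1nc(Nc2ccccc2Cl)c(C#N)c(-c2ccccc2)n1` gives 12400 nM; the step of a 1.3-fold higher number from compound 1 to compound 2 (0.11 log units; within the scatter) exchanges one aryl group for another on the nitrogen attached to the shared core and leaves the number within the scatter. Compound 3 `N#Cc1c(Nc2ccc(Cl)cc2)nc(SCc2cn(Cc3ccccc3Cl)nn2)nc1-c1ccccc1` gives 1590 nM, the lowest of the three numbers, beyond the scatter from compound 1 and from compound 2.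

Compound 4 `Cc1ccccc1Nc1nc(SCc2cn(Cc3ccccc3Cl)nn2)nc(-c2ccccc2)c1C#N` is not yet measured. It differs from compound 3 in one place: 2-methylphenyl in place of 4-chlorophenyl on a nitrogen on an aromatic ring. The rest of the molecule is unchanged. Among the measured compounds shown here, the only measured step that bears on this change is the aryl exchange on the same nitrogen from compound 1 to compound 2, which stayed within the scatter; no measured step touches a methylphenyl group. On that precedent the step of a 1.6-fold higher number from compound 3 to compound 4 (0.20 log units; within the scatter) is expected to stay near the scatter, with no firm direction. For compound 4 the estimated value in this assay is 2500 nM, with a range from 1000 nM to 6500 nM.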

Compound 4, half-maximal inhibitory concentration: 2760 nM
Compound 4: middle estimate off by 1.1-fold (0.04 log units), on the low side, and the stated range covers the measured number.
By their numbers in this assay, from the lowest: compounds 3 and 4 (each within the scatter of the next); then compounds 1 and 2 (each within the scatter of the next).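

In this assay, the step of a 1.7-fold higher number from compound 3 to compound 4 (0.24 log units; within the scatter) stays within the scatter, so (2-methylphenyl)amino and (4-chlorophenyl)amino are not distinguished at this position on the shared core. Among the compounds shown here, until now, the only aryl exchange on this nitrogen was a 1.3-fold higher number from compound 1 to compound 2 (0.11 log units; within the scatter) and it was read on a different remainder of the molecule, so the new step extends that within-scatter behaviour to the background of compound 3. No measured evidence offers an explanation for this result.

Compound 3 and compound 4 differ in both the substituent and its printed location on the phenyl ring, so the step cannot separate these two changes. Also open, on these data alone, is how this nitrogen responds to a non-aryl group such as a simple alkyl chain, or to a phenyl ring bearing a carboxylic acid or an amine.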